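Swapping an amino group for pyridin-3-yl: cytotoxicity outlook

The compounds below may be only part of what the source reports. "The series", "measured", "known", "first", "only" and "open" are said of these compounds alone.

Measured compounds and their values in an ADME assay on THP-1 cells (Homo sapiens) for cytotoxicity, read by MTT assay; a lower number here means that less compound is tolerated, a higher number that more compound is tolerated:
compound 1 `COc1ccc(-c2cc(-c3cc(OC)c(OC)c(OC)c3)nc(N)n2)cc1`: 100000 nM
compound 2 `COc1cc(C2CC(c3ccc(Br)cc3)=NN2C(C)=O)cc(OC)c1OC`: 100000 nM
compound 3 `COc1cc(-c2cc(-c3ccc(Br)cc3)nc(N)n2)cc(OC)c1OC`: 100000 nM

All three measured compounds give the same reading in this assay. Compound 1 stands level with compound 2 and compound 3 at the digits shown; the gaps between them lie within the scatter of repeated measurements, so no order can be drawn from them. For the measured compounds named here, the one step that links two measured compounds differing in a single place, no change at the digits printed from compound 1 to compound 3 (within the scatter), shows that exchanging one substituent on an aromatic carbon of the outer ring left tolerance of the compound unchanged.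

The unmeasured compound 4 `COc1ccc(-c2cc(-c3cc(OC)c(OC)c(OC)c3)nc(-c3cccnc3)n2)cc1` departs from compound 1 at a different place: pyridin-3-yl in place of amino on an aromatic carbon. Going by the values given here, no measured step touches this position of the shared core, so the only guidance is that every change recorded so far has left this assay untouched. On that basis compound 4 is expected to be tolerated at about the same level as compound 1, an expected step of no change at the digits printed from compound 1 to compound 4 (within the scatter), meaning no shift beyond the scatter. The estimate for compound 4 is therefore 100000 nM, with an expected range from 20000 nM to 100000 nM.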

Compound 4, half-maximal cytotoxic concentration: 200000 nM
Compound 4: the middle estimate sits 2.0-fold (0.30 log units) below what was measured; the whole stated range lies below it.
By their numbers in this assay, from the lowest: compounds 1, 2, 3 and 4 (each within the scatter of the next).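

At this position of the shared core, on an aromatic carbon between two ring nitrogen atoms, replacing amino with pyridin-3-yl in this assay gives a 2.0-fold higher number from compound 1 to compound 4 (0.30 log units; within the scatter). For the compounds shown here, the earlier single-place step covered only bromo in place of methoxy on an outer ring, so this is the first reading for the position itself. It shows that a single amino group can give way to pyridin-3-yl, a six-membered aromatic ring of 6 heavy atoms with 0 hydrogen-bond donors, without the reading moving beyond the scatter, and no measurement here explains why the reading holds.

This single replacement cannot show how other groups behave at the position: a carboxylic acid, a morpholine ring or a longer aminoalkyl chain might stay within the scatter of compound 1 or might bring the number down beyond it. It is also open whether pyridin-3-yl would give the same result with bromo on the outer ring, as in compound 3, since that pairing does not appear among these compounds.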